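Swapping the Fluorinated Ring for an Isopropoxy Ring

This account rests on a few compounds, and the source may have more. Where it says the series, first, only, none or still open, it means among the compounds named here.

Measured so far:
- compound 1 `C[C@@H](C(=O)N[C@H](C#N)CC(N)=O)N(Cc1ccc(-c2cc(F)cc(F)c2)cc1)S(C)(=O)=O` — 1360 nM
- compound 2 `C[C@H](C(=O)N[C@H](C#N)CC(N)=O)N(Cc1ccc(-c2cc(F)cc(F)c2)cc1)S(C)(=O)=O` — 9250 nM
- compound 3 `CC(C(=O)N[C@H](C#N)CC(N)=O)N(Cc1ccc(-c2cccc(Cl)c2)cc1)S(C)(=O)=O` — 425 nM

In an assay on isolated protein for inhibition of legumain (Homo sapiens), with stated times of 2 min and 60 min (a lower number here means a stronger inhibitor, a higher number a weaker inhibitor), compound 1 stands second highest of the three numbers: compound 3 gives 425 nM, and compound 2 gives 9250 nM. Within the data shown here, the only single-change step so far is a 6.8-fold higher number from compound 1 to compound 2 (0.83 log units; beyond the scatter), which rests on (the fact that compounds 1 and 2 differ only in the configuration as drawn). Compound 3 differs from compound 1 in more than one place, so its value is noted without drawing a step from it.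

Compound 4 `CC(C)Oc1cccc(-c2ccc(CN([C@@H](C)C(=O)N[C@H](C#N)CC(N)=O)S(C)(=O)=O)cc2)c1` keeps everything of compound 1 except that it carries 3-isopropoxyphenyl in place of 3,5-difluorophenyl on an aromatic carbon. Among the measured compounds shown here, no measured step changes this ring, so nothing here sets the size or direction of the effect. A modest step in this assay, inside or just beyond the scatter, is expected; the estimate is a 1.5-fold lower number from compound 1 to compound 4 (0.18 log units; within the scatter). Compound 4 is therefore expected to give about 900 nM, between 250 nM and 3500 nM.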

Compound 4, half-maximal inhibitory concentration: 882 nM
The estimate for compound 4 lay 1.0-fold (0.01 log units) above the measured number, and the stated range covers the measured number.
By their numbers in this assay, from the lowest: compound 3; then compounds 4 and 1 (each within the scatter of the next); then compound 2.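

In this assay, exchanging 3,5-difluorophenyl for 3-isopropoxyphenyl gives a 1.5-fold lower number from compound 1 to compound 4 (0.19 log units; within the scatter), so this step cannot be told apart from the ordinary spread of repeat measurements. Among these compounds, this is the first look at this position, on an aromatic carbon para to a large group, and it can hold either ring without a readable difference, even though 3-isopropoxyphenyl has more heavy atoms and brings a hydrogen-bond acceptor that 3,5-difluorophenyl lacks. Nothing measured here accounts for why the two rings read alike.

Going by these compounds, whether a ring carrying an amine or a carboxylic acid would also be accepted at this position remains open. Compound 3 differs from compound 4 in more than one place, so its 3-chlorophenyl ring cannot yet be compared directly with this pair.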